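This account rests on a few compounds, and the source may have more. Where it says the series, first, only, none or still open, it means among the compounds named here.

Three compounds share a core and differ only in the aryl group on the amide carbonyl. Compound 1 `O=C(Nc1cccc(-c2oc3cc(-c4ccc(F)cc4)ccc3c(=O)c2O)c1)c1ccc(Cl)cc1` gives 11000 nM in a functional assay on HepG2 cells (Homo sapiens) for antiproliferative activity, read by CCK-8 assay, with a stated time of 72 h; on this read-out higher numbers stand for weaker inhibition and lower numbers for stronger inhibition. Compound 2 `O=C(Nc1cccc(-c2oc3cc(-c4ccc(F)cc4)ccc3c(=O)c2O)c1)c1ccc(Br)cc1F` reaches only the limit of > 100000 nM in this assay. Compound 3 `COc1ccc(C(=O)Nc2cccc(-c3oc4cc(-c5ccc(F)cc5)ccc4c(=O)c3O)c2)c(F)c1` gives 45300 nM, the highest of the two numbers; the step of a 4.1-fold higher number from compound 1 to compound 3 (0.61 log units; beyond the scatter) and the step of an at least 2.2-fold lower number from compound 2 to compound 3 (0.34 log units; beyond the scatter) are both beyond the scatter, as is an at least 9.0-fold higher number from compound 1 to compound 2 (0.95 log units; beyond the scatter). Compound 4 `O=C(Nc1cccc(-c2oc3cc(-c4ccc(F)cc4)ccc3c(=O)c2O)c1)c1cc(F)cc(F)c1` carries 3,5-difluorophenyl in place of 2-fluoro-4-methoxyphenyl on a carbonyl carbon. Since a halogen-only aryl gave either the number of compound 1 or the limit of compound 2, the direction is uncertain, and compound 4 is expected to land near compound 3 with a 1.5-fold lower number from compound 3 to compound 4 (0.18 log units; within the scatter), estimated at 30000 nM within 8000 nM to 100000 nM.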

Compound 4, half-maximal inhibitory concentration: 4960 nM
Estimate against measurement, compound 4: 6.0-fold (0.78 log units) above, and the stated range ends above it.
By their numbers in this assay, from the lowest: compound 4; then compound 1; then compound 3. At a limit, above all of these: compound 2.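

Putting 3,5-difluorophenyl on the amide carbonyl gives a 9.1-fold lower number from compound 3 to compound 4 (0.96 log units; beyond the scatter) and a 2.2-fold lower number from compound 1 to compound 4 (0.35 log units; beyond the scatter), which makes compound 4 the most potent of the four in this assay. Compound 2 stands at a limit of the assay, so an at least 20-fold lower number from compound 2 to compound 4 (1.30 log units; beyond the scatter) is only a bound: the limit of > 100000 nM in this assay, at which 1 of the 4 values shown sits. Carrying only halogens on this aryl group therefore does not settle the outcome, as compound 1, compound 2 and compound 4 all do so yet differ clearly. Still open, on these data alone, is how this position would respond to an aryl group bearing an amine or a carboxylic acid, or to a cyclohexyl group in place of the aryl ring.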